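This account rests on a few compounds, and the source may have more. Where it says the series, first, only, none or still open, it means among the compounds named here.

Of the compounds shown here, three with a shared core have been measured in a functional assay on DU-145 cells (Homo sapiens) for inhibition, read by trypan blue exclusion, with a stated time of 96 h; on this read-out higher numbers stand for weaker inhibition of growth and lower numbers for stronger inhibition of growth. Compound 1 `CN(C)c1ccc(/C=C(/Sc2ccc(Br)cc2)C(=O)c2ccc(Cl)cc2)cc1` gives only a limit, > 100000 nM, which is a boundary of the assay rather than a number (the limit of > 100000 nM in this assay, at which 1 of the 3 values shown sits). Compound 2 `COc1ccc(/C=C(/SCc2ccc(Cl)cc2)C(=O)c2ccc(Cl)cc2)cc1` gives 10000 nM. Compound 3 `O=C(/C(=C\c1ccc(OCc2ccccc2)cc1)SCc1ccc(Cl)cc1)c1ccc(Cl)cc1` gives 1000 nM, the lowest of the two numbers shown, with compound 2 the nearest to it. Within the data shown here, the only step measured at both ends is a 10-fold lower number from compound 2 to compound 3 (1.00 log units; beyond the scatter), which is beyond the scatter.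

Compound 4 `CN(C)c1ccc(/C=C(/SCc2ccc(Cl)cc2)C(=O)c2ccc(Cl)cc2)cc1` differs from compound 3 by dimethylamino in place of benzyloxy on an aromatic carbon. Among the measured compounds shown here, no measured step shows exactly this change. For the measured compounds named here, the step from compound 2 to compound 3 touches the same position but with a different group, and compound 1 carries dimethylamino at that position while differing elsewhere, so it offers no direct step. Because a 10-fold lower number from compound 2 to compound 3 (1.00 log units; beyond the scatter) came with adding the phenyl, removing the benzyloxy is expected to move the number back toward that of compound 2, with a 10-fold higher number from compound 3 to compound 4 (1.00 log units; beyond the scatter). Compound 4 is therefore expected to give 10000 nM, within a range from 2000 nM to 60000 nM.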

Compound 4, concentration for 50% growth inhibition: > 100000 nM
Compound 4: only a limit was reported; the forecaster's own chance of this, stated with the estimate: 25%; middle value at least 10-fold (1.00 log units) away from the limit.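

With the 4-chlorobenzyl on sulfur held constant, the group on this aromatic carbon can do more than the earlier step suggested: dimethylamino in place of benzyloxy gives an at least 100-fold higher number from compound 3 to compound 4 (2.00 log units; beyond the scatter), and dimethylamino in place of methoxy gives an at least 10-fold higher number from compound 2 to compound 4 (1.00 log units; beyond the scatter). Compound 1 also carries dimethylamino but differs on sulfur, and its step to compound 4 cannot be read, so only these new steps show dimethylamino falling behind both oxygen-linked groups. The full size of both steps stays unknown, as compound 4 gives only a limit in this assay: the limit of > 100000 nM in this assay, at which 2 of the 4 values shown sit.

The compounds shown leave open whether the loss follows from the nitrogen itself or from the missing ring of benzyloxy. A benzylamino group at this position would keep that ring while linking it through nitrogen, and so would separate the two.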